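Removing the Amide Methyl: Compound 1 to Compound 4

The source may report more compounds than this note shows. Statements on the series, on what has been measured and on what is new or still open speak of the compounds shown alone.

Compound 1 `CN(C(=O)c1cc(F)ccc1O)c1ccc(C#N)cc1` was tested in a functional assay on HL-60 cells (Homo sapiens) for cytotoxicity, read by luminescence and CellTiter-Glo, with a stated time of 3 days; on this read-out higher numbers stand for weaker inhibition and lower numbers for stronger inhibition. In this assay compound 1 gives only a limit of the assay, > 10000 nM. Two related compounds with a hydrogen on the amide nitrogen were also measured: compound 2 `N#Cc1ccc(NC(=O)c2ccc3ccccc3c2O)cc1` gives 3410 nM in this assay, and compound 3 `N#Cc1ccc(NC(=O)c2ccc(-c3ccncc3)cc2O)cc1` gives 7090 nM. Compound 4 `N#Cc1ccc(NC(=O)c2cc(F)ccc2O)cc1` differs from compound 1 in one place, (hydrogen in place of methyl on an amide-type nitrogen). Compound 1 sits at the limit of > 10000 nM in this assay, at which 1 of the 3 values shown sits, so the size of the step cannot be read directly from compound 1 alone. Drawing on compound 2 and compound 3, the change is expected to strengthen inhibition, with an expected step of an at least 1.6-fold lower number from compound 1 to compound 4 (0.22 log units; that floor lies within the scatter) beyond the usual scatter. Compound 4 is estimated at 6000 nM, with a range from 2000 nM to 20000 nM.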

Compound 4, half-maximal inhibitory concentration: 1420 nM
Beside the measured number, compound 4's estimate is 4.2-fold (0.63 log units) above it; measured number below the stated range.
By their numbers in this assay, from the lowest: compound 4; then compound 2; then compound 3. At a limit, above all of these: compound 1.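

In this assay, putting hydrogen in place of methyl on the amide-type nitrogen brings an at least 7.0-fold lower number from compound 1 to compound 4 (0.84 log units; beyond the scatter). This is the only pair shown that differs in this one place, so it ties the change in number directly to this nitrogen, which compound 2 and compound 3 could not do. The real step may be larger, because compound 1 gives only a limit of the assay: the limit of > 10000 nM in this assay, at which 1 of the 4 values shown sits.

The compounds shown leave open how an ethyl group or a longer chain on this nitrogen would compare. They also leave open whether the same change would carry over to the cores of compound 2 and compound 3.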